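The source may report more compounds than this note shows. Statements on the series, on what has been measured and on what is new or still open speak of the compounds shown alone.

Three compounds of the series carry numbers in an ADME assay on cells (Macrophage, Homo sapiens) for cytotoxicity, read by MTT assay, with a stated time of 48 h; on this read-out lower numbers stand for stronger inhibition and higher numbers for weaker inhibition. Compound 1 `CC/C=C/[C@H](CC)C[C@@]1(C)C[C@@H](CC)[C@@H](CC(=O)OC)OO1` gives 4.7 ug/mL in this assay. Compound 2 `CC/C=C/[C@H](CC)C/C(=C/[C@@]1(CC)C[C@H](CC)[C@H](CC(=O)O)OO1)CC` gives 16.6 ug/mL in this assay. Compound 3 `CC/C=C/[C@H](CC)C[C@]1(CC)C=C(CC)/C(=C/C(=O)OC)O1` gives 30.2 ug/mL in this assay, the highest of the three numbers; its gap to compound 2 lies within the scatter, while its gap to compound 1 lies beyond the scatter, with compound 1 at the lower number. Among the measured compounds shown here, no pair of measured compounds differs in a single place, so no measured step guides the next change.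

Compound 4 `CC/C=C/[C@H](CC)C[C@]1(C)C=C(CC)/C(=C/C(=O)OC)O1` awaits measurement in this assay. It differs from compound 3 in one place: hydrogen in place of methyl on a saturated chain carbon bound to a saturated ring carbon. For the measured compounds named here, compound 1 also carries methyl rather than ethyl, but its core differs from that of compound 3 in more than one place, so the values of compound 1 and compound 3 show only that compound 1 sits at the lower number and say nothing of this change alone. The step from compound 3 to compound 4 is expected to be small, a 1.2-fold lower number from compound 3 to compound 4 (0.08 log units; within the scatter), with no direction beyond the scatter. Compound 4 is expected to give about 25 ug/mL in this assay, within a range from 10 ug/mL to 60 ug/mL.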

Compound 4, half-maximal inhibitory concentration: 29.8 ug/mL
Beside the measured number, compound 4's estimate is 1.2-fold (0.08 log units) below it; measured number inside the range.
By their numbers in this assay, from the lowest: compound 1; then compounds 2, 4 and 3 (each within the scatter of the next).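

Hydrogen in place of methyl on a saturated chain carbon bound to a saturated ring carbon, which also reads as ethyl to methyl, gives a 1.0-fold lower number from compound 3 to compound 4 (0.01 log units; within the scatter) in this assay and is the first single change that can be read in this series. On the core shared by compound 3 and compound 4, this read-out does not separate ethyl from methyl at this place. No supporting data accompany the step that could account for this result.

As far as these compounds go, whether a longer chain, a carboxylic acid or an amine at this place would also stay within the scatter remains open. Also open, from the compounds shown here alone, is whether ethyl to methyl reads the same on the cores of compound 1 and compound 2, since one step on one core sets no pattern.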